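This account rests on a few compounds, and the source may have more. Where it says the series, first, only, none or still open, it means among the compounds named here.

Of the compounds shown here, three share one core and have been tested in an assay on cells for antagonist activity at vitamin D3 receptor (Homo sapiens), read by a luciferase reporter; on this read-out lower numbers stand for stronger inhibition and higher numbers for weaker inhibition. Compound 1 `COC(=O)c1ccccc1OCc1oc(-c2ccccc2OC)nc1C` gives 20200 nM. Compound 2 `COC(=O)CCc1ccc(OCc2oc(-c3ccccc3OC)nc2C)cc1` gives 13600 nM. Compound 3 `COC(=O)CCc1ccc(OCc2oc(-c3cccc(OC)c3)nc2C)cc1` gives 6700 nM. The only change between two of these compounds that is confined to a single place is the one between compounds 2 and 3, which brings a 2.0-fold lower number from compound 2 to compound 3 (0.31 log units; beyond the scatter). On these three numbers compound 3 stands lowest, with compound 2 nearest and compound 1 furthest.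

Compound 4 `COc1cccc(-c2nc(C)c(COc3ccc(CC(=O)O)cc3)o2)c1` is not yet measured. It differs from compound 3 in one place: carboxy in place of (methoxycarbonyl)methyl on a saturated chain carbon bound to an aromatic carbon. Within the data shown here, none of the measured steps touches this part of the molecule; each change seen so far concerns the methoxyphenyl group on the other side of the core. Among the measured compounds shown here, there is therefore no measured step that bears on this change, and no direction is indicated by the data. The expected outcome is a step of no size beyond the scatter, so that compound 4 is estimated at 6500 nM, within a range from 2000 nM to 22000 nM. The step this estimate means is a 1.0-fold lower number from compound 3 to compound 4 (0.01 log units; within the scatter).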

Compound 4, half-maximal inhibitory concentration: 27700 nM
Beside the measured number, compound 4's estimate is 4.3-fold (0.63 log units) below it; measured number outside the range, above it.
By their numbers in this assay, from the lowest: compound 3; then compounds 2, 1 and 4 (each within the scatter of the next, the first and the last beyond it).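

In this assay, among these compounds, this end of the molecule proves sensitive, and the change brings a 4.1-fold higher number from compound 3 to compound 4 (0.62 log units; beyond the scatter), so inhibition weakens where the only earlier single-place step concerned the methoxyphenyl group. Cut one bond further out, the same difference reads 2-(methoxycarbonyl)ethyl to carboxymethyl, so the methyl ester gives way to a free acid and the chain shortens in a single step. Nothing measured here offers an explanation for the weaker inhibition.

The compounds shown leave open whether the loss follows the carboxylic acid, the shorter chain or both together. A carboxylic acid on the longer chain, or a methyl ester on the shorter one, would separate these two changes, and a primary amide on either chain would show whether other groups are tolerated here.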